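A Hydroxyethyl Group Replaces Benzyl on the Shared Core

The source may report more compounds than this note shows. Statements on the series, on what has been measured and on what is new or still open speak of the compounds shown alone.

The measured compounds and their numbers:
Compound 1, `O=C(N[C@H]1CC[C@@H](c2ccccc2)CC1)c1[nH]c(=O)[nH]c(=O)c1O`: in an assay on isolated protein for inhibition of endothelial lipase (Homo sapiens), read by LC-MS, with a stated time of 2 h, in the presence of a further agent that is not named here (a higher number here means a weaker inhibitor, a lower number a stronger inhibitor), compound 1 gives 25000 nM.
Compound 2, `CC(C)Cn1c(=O)[nH]c(C(=O)N[C@H]2CC[C@@H](c3ccccc3)CC2)c(O)c1=O`: in this assay compound 2 gives 48000 nM.
Compound 3, `O=C(N[C@H]1CC[C@@H](c2ccccc2)CC1)c1[nH]c(=O)n(Cc2ccccc2)c(=O)c1O`: in this assay compound 3 gives 32000 nM.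

Compound 3 has the second highest of the three numbers. Its nearest neighbour is compound 1, with a 1.3-fold higher number from compound 1 to compound 3 (0.11 log units; within the scatter), and its furthest is compound 2, with a 1.5-fold lower number from compound 2 to compound 3 (0.18 log units; within the scatter); both gaps sit within the scatter, so the three compounds cannot be told apart on these numbers.

Compound 4, `O=C(N[C@H]1CC[C@@H](c2ccccc2)CC1)c1[nH]c(=O)n(CCO)c(=O)c1O`, differs from compound 3 in one place: hydroxymethyl in place of phenyl on a saturated chain carbon bound to an aromatic nitrogen.

Among the measured compounds shown here, three measured steps bear on this change, all at the same place on the shared core. Adding isobutyl gave a 1.9-fold higher number from compound 1 to compound 2 (0.28 log units; within the scatter), adding benzyl gave a 1.3-fold higher number from compound 1 to compound 3 (0.11 log units; within the scatter), and exchanging isobutyl for benzyl gave a 1.5-fold lower number from compound 2 to compound 3 (0.18 log units; within the scatter). None of them moved the number beyond the scatter, so groups at this position have so far made no visible difference in this assay. A group carrying a hydroxyl has not yet been tested here, which leaves some room for surprise.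

On that basis compound 4 is expected to show a 1.1-fold lower number from compound 3 to compound 4 (0.03 log units; within the scatter), that is, no step beyond the scatter. The estimate for compound 4 in this assay is 30000 nM, with a range from 10000 nM to 90000 nM.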

Compound 4, half-maximal inhibitory concentration: > 143000 nM
Compound 4: no number, only a limit (the forecaster's own chance of this, stated with the estimate: 15%); middle value at least 4.7-fold (0.67 log units) away from the limit.
By their numbers in this assay, from the lowest: compounds 1, 3 and 2 (each within the scatter of the next). At a limit, above all of these: compound 4.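

In this assay, compound 4 gives no number, only a limit: the limit of > 143000 nM in this assay, at which 1 of the 4 values shown sits. Every step to it lies beyond the scatter, which no earlier change at this place did: 2-hydroxyethyl in place of benzyl gives an at least 4.4-fold higher number from compound 3 to compound 4 (0.65 log units; beyond the scatter), hydroxymethyl in place of isopropyl on the saturated chain carbon gives an at least 2.9-fold higher number from compound 2 to compound 4 (0.47 log units; beyond the scatter), and 2-hydroxyethyl in place of hydrogen on the aromatic nitrogen gives an at least 5.7-fold higher number from compound 1 to compound 4 (0.75 log units; beyond the scatter). The aromatic nitrogen of the shared core is therefore not indifferent to what it carries: hydrogen, isobutyl and benzyl stay within the scatter of one another, while 2-hydroxyethyl stands apart from all three.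

Going by these compounds, whether this step comes from the short chain or from the hydroxyl at its end stays open, and a plain ethyl group on the aromatic nitrogen would separate the two. An amine or a carboxylic acid at the end of the same chain would show whether the step is peculiar to the hydroxyl or extends to other groups placed there.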